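Pyrazinyl for pyridinyl on the aryl amine

The compounds below may be only part of what the source reports. "The series", "measured", "known", "first", "only" and "open" are said of these compounds alone.

Measured compounds:
- compound 1 `Cc1ncc(CO)c2c(Nc3cnccn3)c(NCc3ccccc3)oc12`: 9790 nM
- compound 2 `Cc1ncc(CO)c2c(Nc3cnccn3)c(NC(C)(C)C)oc12`: "not active" (no number reported)
- compound 3 `Cc1ncc(CO)c2c(Nc3ccccn3)c(NC3CCCCC3)oc12`: 6930 nM

In a functional assay on HEK293 cells for agonist activity at Toll-like receptor 8 (Homo sapiens), read by reporter gene assay (a higher number here means that more compound is needed for the effect, a lower number that less compound is needed), compound 3 gives 6930 nM. Of the two numbers in hand this is the lower one, but the gap to compound 1, which in this assay gives 9790 nM, lies within the scatter, so the two cannot be ordered. Among the compounds with values here, compound 2 gives "not active" (no number reported) in this assay, so only two numbers exist.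

Compound 4 `Cc1ncc(CO)c2c(Nc3cnccn3)c(NC3CCCCC3)oc12` is not yet measured. It differs from compound 3 in one place: pyrazin-2-yl in place of pyridin-2-yl on a nitrogen on an aromatic ring. Within the data shown here, no pair of measured compounds differs in this way alone, so no step for this change is known. What is known is that both compounds carrying the pyrazin-2-yl group, compound 1 and compound 2, sit at a high number or give no number at all, while compound 3 with pyridin-2-yl sits in the same high region as compound 1.

The expectation for compound 4 is therefore a number close to that of compound 3, with the step of a 1.2-fold higher number from compound 3 to compound 4 (0.09 log units; within the scatter) not clearly beyond the scatter. Compound 4 is estimated at 8500 nM, in the range 3000 nM to 30000 nM, with a real chance that this assay reports no number.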

Compound 4, half-maximal effective concentration: 10600 nM
The estimate for compound 4 lay 1.2-fold (0.10 log units) below the measured number; low and high end bracket the measured number.
By their numbers in this assay, from the lowest: compounds 3, 1 and 4 (each within the scatter of the next).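

The pyridin-2-yl to pyrazin-2-yl change now has a direct pair: in this assay it gives a 1.5-fold higher number from compound 3 to compound 4 (0.18 log units; within the scatter) and so, on this nitrogen and with cyclohexyl held fixed, the two rings cannot be told apart. With pyrazin-2-yl held fixed, cyclohexyl in place of benzyl gives a 1.1-fold higher number from compound 1 to compound 4 (0.03 log units; within the scatter) and so also shows no separable change, which leaves compound 1 and compound 4 in the same high region. Pyrazin-2-yl alone therefore does not remove the read-out, since compound 4 carries it and gives a number, while compound 2, with tert-butyl in place of cyclohexyl, gives "not active" (no number reported) in the same assay.

As far as these compounds go, it remains open whether phenyl or pyrimidin-2-yl on this nitrogen would give a number clearly apart from these values. From the compounds shown here alone, it is equally open whether a primary amine or a carboxylic acid on the cyclohexyl group would move the number beyond the scatter. No measurement in hand accounts for where any of these values fall.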